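Swapping Chloro for Hydroxy on a Shared Core

The source may hold more compounds than are shown below. What is called first, only, known or untested is meant among the compounds shown, and "the series" means these compounds.

Of the compounds shown here, two have been tested in a functional assay on B16 cells (Mus musculus) for inhibition, tested at 10 uM; a higher number here means more inhibition at the concentration tested (going by the name of the read-out), a lower number less inhibition. Compound 1 `Cc1cccc(/C=N/NC(N)=S)c1` carries a methyl group on its aromatic ring. In this assay compound 1 gives > 100%, which is a limit of the assay rather than a number. Compound 2 `NC(=S)N/N=C/c1cccc(Cl)c1` carries a chloro group where compound 1 has the methyl. In this assay compound 2 reaches > 100%, again a limit of the assay and not a number. The step that the two limits leave unreadable from compound 1 to compound 2 therefore has no readable size; both results sit at the same limit, as the limit of > 100% in this assay, at which 2 of the 2 values shown sit, shows. Compound 3 `NC(=S)N/N=C/c1cccc(O)c1` has not yet been measured. It differs from compound 2 by hydroxy in place of chloro on an aromatic carbon. Going by the values given here, no measured step covers such a change, and the one step available is unreadable, so the step of a number at least 5 percentage points lower from compound 2 to compound 3 (that floor lies within the scatter) is expected to be small, with compound 3 staying near the limit. Compound 3 is estimated to give 95%, within a range from 70% to 100%.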

Compound 3, a percentage reported as inhibition, at one concentration (the size of the read-out at that concentration, not a potency): 28%
Beside the measured number, compound 3's estimate is 67 percentage points above it; the measured number lies below the stated range.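

This place on the aromatic ring is not indifferent to the group it carries: in this assay, hydroxy in place of chloro gives a number at least 72 percentage points lower from compound 2 to compound 3 (beyond the scatter), and hydroxy in place of methyl gives a number at least 72 percentage points lower from compound 1 to compound 3 (beyond the scatter). Going by these compounds alone, the step between compound 1 and compound 2 cannot be read, so these are the first readable changes at this place, and the earlier results rest on a limit of the assay rather than on numbers: the limit of > 100% in this assay, at which 2 of the 3 values shown sit. Hydroxy brings a hydrogen-bond donor and a hydrogen-bond acceptor that chloro lacks, but these compounds cannot show whether that difference is what matters.

Going by these compounds, it remains open how a methoxy group, an amine or a carboxylic acid would read out at this same place. Also open, on these data alone, is how far methyl and chloro really differ.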